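The compounds below may be only part of what the source reports. "The series", "measured", "known", "first", "only" and "open" are said of these compounds alone.

Three compounds of this series have been measured in an ADME assay on HEp-2 cells (Homo sapiens) for cytotoxicity, read by MTT assay, with a stated time of 3 days; on this read-out higher numbers stand for lower toxicity in this test and lower numbers for higher toxicity in this test:

compound 1, `CCCC[C@@H](CCn1cncn1)c1ccccc1`, compound 1 gives 40.8 ug/mL
compound 2, `CCCC[C@@H](CCn1cncn1)c1ccc(C)cc1`, compound 2 gives 60.7 ug/mL
compound 3, `c1ccc(C[C@H](CCn2cncn2)c2ccccc2)cc1`, compound 3 gives 60.9 ug/mL

Compound 1 and compound 2 share one core and differ by methyl in place of hydrogen on an aromatic carbon. The step is a 1.5-fold higher number from compound 1 to compound 2 (0.17 log units; within the scatter), so within the scatter of this assay the two numbers are not distinguishable. Compound 3 carries a different core; the difference between the two cores is not broken down here. Its value in this assay lies within the scatter of the values of compound 1 and of compound 2, so no order among the three can be stated.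

Compound 4, `Cc1ccc(C[C@H](CCn2cncn2)c2ccccc2)cc1`, has not been measured in this assay. Going by the values given here, it differs from compound 3 by methyl in place of hydrogen on an aromatic carbon, which is the same change as the one from compound 1 to compound 2, made on the same kind of place. Because the earlier step was a 1.5-fold higher number from compound 1 to compound 2 (0.17 log units; within the scatter), a step of a similar, small size is expected here, with the estimate resting on that single precedent and on the value of compound 3, 60.9 ug/mL. Compound 4 is therefore expected to give 75 ug/mL in this assay, estimated to lie between 40 ug/mL and 130 ug/mL. This estimate means an expected step of a 1.2-fold higher number from compound 3 to compound 4 (0.09 log units; within the scatter).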

Compound 4, half-maximal cytotoxic concentration: 38.8 ug/mL
Beside the measured number, compound 4's estimate is 1.9-fold (0.29 log units) above it; the measured number lies below the stated range.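

In this assay, methyl in place of hydrogen on an aromatic carbon, here phenyl to 4-methylphenyl, gives a 1.6-fold lower number from compound 3 to compound 4 (0.20 log units; within the scatter), so on this core the two numbers cannot be told apart. Set beside the earlier step on the other core, the new step shows no difference that exceeds what repeated measurement would produce: the same change on two cores in this assay, a 1.5-fold higher number (0.17 log units; within the scatter) from compound 1 to compound 2 and a 1.6-fold lower number (0.20 log units; within the scatter) from compound 3 to compound 4, 2.3-fold (0.37 log units) apart, within the scatter of two such steps. What this shows is that the change gave no readable step on either core in this assay, while it does not show that the change acts alike on both cores, and the opposite signs of the two steps establish neither a real reversal nor a shared direction, as both are single steps within the scatter.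

Methyl is the only added group among the compounds shown, so it remains open whether a group such as methoxy, an amine or a carboxylic acid in that place would give a step beyond the scatter on either core. As far as these compounds go, it also remains open whether a step of that kind would carry from one core to the other, as a comparison of that sort needs steps that can be read on both cores.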